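From methyl to oxetan-3-yl on an amide nitrogen

The compounds below may be only part of what the source reports. "The series", "measured", "known", "first", "only" and "open" are said of these compounds alone.

In a functional assay (strain AB) with Danio rerio as the target, read by microscopy, with a stated time of 1 h (on this read-out lower numbers stand for an effect already at smaller amounts and higher numbers for an effect only at larger amounts of compound), compound 2 (`CCN1CCc2c(sc(NC(=O)Nc3ccc(Cl)cc3)c2C(=O)NC)C1`) gives > 25000 nM, which is a limit of the assay and not a number. Two related compounds do give numbers: compound 1 (`CCN1CCc2c(sc(NC(=O)Nc3ccc4ccccc4c3)c2C(N)=O)C1`) gives 1780 nM, and compound 3 (`CC(C)(C)OC(=O)CCCN1CCc2c(sc(NC(=O)Nc3ccc(Cl)cc3)c2C(N)=O)C1`) gives 560 nM. Compound 2 is therefore the only one of the three without a measured number.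

Compound 4 (`CCN1CCc2c(sc(NC(=O)Nc3ccc(Cl)cc3)c2C(=O)NC2COC2)C1`) has oxetan-3-yl in place of methyl on an amide-type nitrogen. Going by the values given here, compound 1 and compound 3 each differ from compound 2 in more than one place, so no measured step shows what this single swap does.

The expectation therefore starts from the limit of compound 2, > 25000 nM, and assumes little movement, with no clear gain beyond the usual scatter in this assay. The expected step is small: a number no higher from compound 2 to compound 4 (the limit leaves the size open). For compound 4 the estimated value is 25000 nM, within an expected range of 8000 nM to 50000 nM. A report of only a limit would be no surprise.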

Compound 4, half-maximal effective concentration: > 25000 nM
Compound 4: only a limit was reported (the forecaster's own chance of this, stated with the estimate: 70%); the middle value lies on the limit itself.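

Compound 2 and compound 4 each give only a limit and not a number, so no step can be read between them: the limit of > 25000 nM in this assay, at which 2 of the 4 values shown sit.

The compounds shown leave open whether oxetan-3-yl in place of methyl on an amide-type nitrogen changes the effect at all, and in which direction.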